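The source may report more compounds than this note shows. Statements on the series, on what has been measured and on what is new or still open speak of the compounds shown alone.

Measured so far:
- compound 1 `CC#CC(CC(=O)O)c1ccc(OCc2ccc(C(=O)N3CCN(Cc4ccccc4)CC3)s2)cc1`: 155 nM
- compound 2 `CC#CC(CC(=O)O)c1ccc(OCc2ccc(C(=O)N3CCN(C)CC3)s2)cc1`: > 5000 nM (a limit of the assay, not a number)
- compound 3 `CC#CC(CC(=O)O)c1ccc(OCc2ccc(C(=O)N3CCN(C4CCCCC4)CC3)s2)cc1`: 820 nM

In a functional assay on HEK293 cells for agonist activity at Free fatty acid receptor 1 (Homo sapiens), read by fluorescence and calcium flux (a lower number here means that less compound is needed, a higher number that more compound is needed for the effect), compound 3 gives the higher of the two numbers; its nearest neighbour is compound 1, with a 5.3-fold higher number from compound 1 to compound 3 (0.72 log units; beyond the scatter). Compound 2 sits at a limit, (the limit of > 5000 nM in this assay, at which 1 of the 3 values shown sits). Compound 4 `CC#CC(CC(=O)O)c1ccc(OCc2ccc(C(=O)N3CCN(c4ccncc4)CC3)s2)cc1` differs from compound 3 in one place: pyridin-4-yl in place of cyclohexyl on an amine nitrogen in a ring. Among the compounds with values here, two measured steps touch this ring nitrogen: a 5.3-fold higher number from compound 1 to compound 3 (0.72 log units; beyond the scatter) and an at least 6.0-fold lower number from compound 2 to compound 3 (0.78 log units; beyond the scatter). Neither places a ring directly on the nitrogen, so the pyridin-4-yl change is only loosely guided; a step within the scatter is expected, a 1.4-fold lower number from compound 3 to compound 4 (0.14 log units; within the scatter). Compound 4 is therefore estimated at 600 nM, in the range 150 nM to 3000 nM.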

Compound 4, half-maximal effective concentration: > 5000 nM
Compound 4: only a limit was reported; the forecaster's own chance of this, stated with the estimate: 12%; middle value at least 8.3-fold (0.92 log units) away from the limit.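

Swapping cyclohexyl for pyridin-4-yl on the amine nitrogen gives an at least 6.0-fold higher number from compound 3 to compound 4 (0.78 log units; beyond the scatter), so a six-membered ring here does not by itself preserve the effect, and the kind of ring matters. Set against benzyl, the same group gives an at least 32-fold higher number from compound 1 to compound 4 (1.50 log units; beyond the scatter). Compound 4 gives > 5000 nM, which is a limit and not a number, and its step to compound 2 cannot be read, with both compounds at the same limit: the limit of > 5000 nM in this assay, at which 2 of the 4 values shown sit.

On these data alone, whether the pyridine nitrogen or the flat aromatic ring drives this loss stays open. A phenyl group on the same amine nitrogen would separate these two readings.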